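The source may report more compounds than this note shows. Statements on the series, on what has been measured and on what is new or still open speak of the compounds shown alone.

Working notes on the series, read in a functional assay on HCT-116 cells (Homo sapiens) for antiproliferative activity, read by MTT assay, with a stated time of 72 h; on this read-out higher numbers stand for weaker inhibition and lower numbers for stronger inhibition: compound 1 `Cc1ccc(N2CCN(C(=S)SCc3ccc4nc(N)nc(N)c4c3)CC2)c(C)c1` gives 4070 nM, compound 2 `Nc1nc(N)c2cc(CSC(=S)N3CCN(c4ccc(F)cc4)CC3)ccc2n1` gives 3270 nM, and compound 3 `CC(=O)c1ccc(N2CCN(C(=S)SCc3ccc4nc(N)nc(N)c4c3)CC2)cc1` gives 8260 nM, the highest number of the three. Compound 4 `Nc1nc(N)c2cc(CSC(=S)N3CCN(c4ccc([N+](=O)[O-])cc4)CC3)ccc2n1` has nitro in place of acetyl on an aromatic carbon, para to a large group: nitro in place of acetyl on an aromatic carbon. The closest evidence is the change at that carbon, a 2.5-fold higher number from compound 2 to compound 3 (0.40 log units; beyond the scatter). The other two steps are a 2.0-fold higher number from compound 1 to compound 3 (0.31 log units; beyond the scatter) and a 1.2-fold lower number from compound 1 to compound 2 (0.10 log units; within the scatter). Going by the values given here, no measured compound carries nitro, so only a small move toward lower numbers, within the scatter, is expected. The estimated step is a 1.4-fold lower number from compound 3 to compound 4 (0.14 log units; within the scatter). Compound 4 is estimated at 6000 nM, with an expected range of 2800 nM to 12000 nM.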

Compound 4, half-maximal inhibitory concentration: 4680 nM
The estimate for compound 4 lay 1.3-fold (0.11 log units) above the measured number; the range from low to high includes it.
By their numbers in this assay, from the lowest: compounds 2, 1, 4 and 3 (each within the scatter of the next, the first and the last beyond it).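

Nitro at this aromatic carbon, para to a large group, cannot be separated from acetyl (a 1.8-fold lower number from compound 3 to compound 4 (0.25 log units; within the scatter)) or from fluoro (a 1.4-fold higher number from compound 2 to compound 4 (0.16 log units; within the scatter)), although fluoro and acetyl themselves are separated (a 2.5-fold higher number from compound 2 to compound 3 (0.40 log units; beyond the scatter)). The 4-nitrophenyl compound also stays within the scatter of the 2,4-dimethylphenyl compound (a 1.1-fold higher number from compound 1 to compound 4 (0.06 log units; within the scatter)). No available evidence bears on what lies behind these readings.

Still open, from the compounds shown here alone, is whether an amine or a carboxylic acid at this carbon would read within the same span. A fluoro-to-acetyl gap this modest also leaves unclear whether this position can move the number much further.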